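Carbonyl substituent changes on the shared core

This account rests on a few compounds, and the source may have more. Where it says the series, first, only, none or still open, it means among the compounds named here.

Compound 3 `COc1ccc2c(c1)OC(c1cc(OC)c(OC)c(OC)c1)C(C=O)=C2` carries a formyl group on a double-bonded ring carbon of the shared core. In a functional assay for inhibition of nuclear factor NF-kappa-B complex (Homo sapiens) (on this read-out higher numbers stand for weaker inhibition and lower numbers for stronger inhibition), compound 3 gives 13500 nM, the lowest of the two numbers on record. Compound 2 `COc1ccc2c(c1)OC(c1cc(OC)c(OC)c(OC)c1)C(C(=O)NC(C)(C)C)=C2`, with a (tert-butyl)carbamoyl group in that position, gives 28400 nM in this assay, and the change is a 2.1-fold lower number from compound 2 to compound 3 (0.32 log units; beyond the scatter). Compound 1 `COc1ccc2c(c1)OC(c1cc(OC)c(OC)c(OC)c1)C(CO)=C2` bears a hydroxymethyl group there. In this assay compound 1 gives only the limit > 50000 nM (the limit of > 50000 nM in this assay, at which 1 of the 3 values shown sits). From compound 1 the steps are an at least 1.7-fold lower number from compound 1 to compound 2 (0.24 log units; that floor lies within the scatter) and an at least 3.7-fold lower number from compound 1 to compound 3 (0.56 log units; beyond the scatter).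

Compound 4 `COc1ccc2c(c1)OC(c1cc(OC)c(OC)c(OC)c1)C(C(=O)Nc1ccccc1)=C2` is not yet measured. It differs from compound 3 in one place: anilino in place of hydrogen on a carbonyl carbon. For the measured compounds named here, the one measured step at this carbonyl carbon is a 2.1-fold lower number from compound 2 to compound 3 (0.32 log units; beyond the scatter); read in reverse, an amino substituent on the carbonyl raised the number modestly. For compound 4 the expected step is a 1.9-fold higher number from compound 3 to compound 4 (0.27 log units; within the scatter) in this assay. For compound 4 the expected value in this assay is 25000 nM, within 10000 nM to 60000 nM.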

Compound 4, half-maximal inhibitory concentration: 17500 nM
Beside the measured number, compound 4's estimate is 1.4-fold (0.15 log units) above it; low and high end bracket the measured number.
By their numbers in this assay, from the lowest: compounds 3, 4 and 2 (each within the scatter of the next, the first and the last beyond it). At a limit, above all of these: compound 1.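

In this assay, anilino on the carbonyl carbon gives a 1.3-fold higher number from compound 3 to compound 4 (0.11 log units; within the scatter), and phenyl on the amide-type nitrogen gives a 1.6-fold lower number from compound 2 to compound 4 (0.21 log units; within the scatter), so compound 4 is separated from neither neighbour, although compounds 2 and 3 lie beyond the scatter of each other. Measured against hydroxymethyl, phenylcarbamoyl gives an at least 2.8-fold lower number from compound 1 to compound 4 (0.45 log units; beyond the scatter), which makes this the first amide step from that compound to clear the scatter, since the floor for the tert-butyl amide stayed within it. Compound 1 holds a limit, not a number: the limit of > 50000 nM in this assay, at which 1 of the 4 values shown sits.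

From the compounds shown here alone, what a carboxylic acid or a methyl ester on this carbonyl carbon would give stays open. So does the effect of a substituted phenyl ring or a simple methyl group on the amide-type nitrogen.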